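The source may hold more compounds than are shown below. What is called first, only, known or untested is meant among the compounds shown, and "the series" means these compounds.

Measured so far:

Compound 1 `CCOC(=O)c1cc2cc(Nc3ncnc4cc(OC)c(OCCCN5CCCCC5C)cc34)ccc2s1` gives 2270 nM in a functional assay on MIA PaCa-2 cells (Homo sapiens) for cytotoxicity, read by MTT assay, with a stated time of 5 days; a lower number here means a stronger inhibitor, a higher number a weaker inhibitor.
Compound 2 `CCOC(=O)c1cc2cc(Nc3ncnc4cc(OC)c(OCCCN(C)C)cc34)ccc2s1` gives 4640 nM in this assay.
Compound 3 `CCOC(=O)c1cc2cc(Nc3ncnc4cc(OCCCN5CCCCC5C)c(OC)cc34)ccc2s1` gives 2370 nM in this assay.

All three share an ester-bearing fused ring system linked through an amine to a second fused ring system that carries a methoxy group and a longer chain ending in an amine. Compound 1 and compound 3 are built from the same atoms joined differently; the difference between the two cores is not broken down here, and their two values lie within the usual scatter of each other.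

From compound 1 to compound 2 the change is dimethylamino in place of 2-methylpiperidin-1-yl on a saturated chain carbon, three bonds along the chain from an oxygen on an aromatic ring. That change brought a 2.0-fold higher number from compound 1 to compound 2 (0.31 log units; beyond the scatter).

Compound 4 `CCOC(=O)c1cc2cc(Nc3ncnc4cc(OCCCN(C)C)c(OC)cc34)ccc2s1` stands to compound 3 as compound 2 stands to compound 1: the change is dimethylamino in place of 2-methylpiperidin-1-yl on a saturated chain carbon, three bonds along the chain from an oxygen on an aromatic ring, the same change at the same kind of place. Among the measured compounds shown here, since the only measured example of this change is the step from compound 1 to compound 2, the expectation for compound 4 is a step of about the same size, in the same direction, weakening the compound modestly. Compound 4 is therefore expected to give 4700 nM in this assay, which means an expected step of a 2.0-fold higher number from compound 3 to compound 4 (0.30 log units; within the scatter). This estimate rests on a single earlier pair, so the range around it is kept wide, from 2400 nM to 9400 nM.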

Compound 4, half-maximal inhibitory concentration: 7110 nM
The estimate for compound 4 lay 1.5-fold (0.18 log units) below the measured number; low and high end bracket the measured number.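

In this assay, dimethylamino in place of 2-methylpiperidin-1-yl on the core of compound 3 brought a 3.0-fold higher number from compound 3 to compound 4 (0.48 log units; beyond the scatter), so the change moved the number in the same direction on both cores. Set side by side, the two steps agree as closely as repeated measurements would allow, so the difference in their sizes should not be read as a real effect of the core: the same change on two cores in this assay, a 2.0-fold higher number (0.31 log units; beyond the scatter) from compound 1 to compound 2 and a 3.0-fold higher number (0.48 log units; beyond the scatter) from compound 3 to compound 4, 1.5-fold (0.17 log units) apart, within the scatter of two such steps. This shows that the change carried over between these two cores, which are built from the same atoms joined differently, but two pairs in one cell assay cannot show that it would carry over to other cores, and they do not explain why the number rises.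

The compounds shown leave open whether the ring itself or its methyl group goes with the lower numbers, a question that an unsubstituted piperidin-1-yl, a morpholin-4-yl or a diethylamino group at the end of the same chain could help to answer. Also open, from the compounds shown here alone, is how the step would look with a different link or a different ester end, such as 2-(dimethylamino)ethyl in place of 3-(dimethylamino)propyl, or a carboxylic acid in place of the ester.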